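Lactam to Cyclohexyl: Estimating Compound 4

This account rests on a few compounds, and the source may have more. Where it says the series, first, only, none or still open, it means among the compounds named here.

Compound 1, `C[C@@]1(O)CC(=O)OC(CSc2nc(-c3ccccc3)c(-c3ccccc3)[nH]2)C1`: 170 nM
Compound 2, `CC(O)(CC(=O)OC(C)(C)C)CC(O)CSc1nc(-c2ccc(Cl)cc2)c(-c2ccc(Cl)cc2)[nH]1`: 250 nM
Compound 3, `O=C1CCC(CSc2nc(-c3ccccc3)c(-c3ccccc3)[nH]2)N1`: 360 nM

In an assay on microsomes from liver for inhibition of sterol O-acyltransferase 1 (Rattus norvegicus) (a lower number here means a stronger inhibitor, a higher number a weaker inhibitor), compound 3 gives 360 nM, the highest of the three numbers; compound 2 sits within the scatter of it, while compound 1 sits beyond. Going by the values given here, the only measured step at this carbon, a 2.1-fold higher number from compound 1 to compound 3 (0.33 log units; beyond the scatter), was modest. Compound 4, `c1ccc(-c2nc(SCC3CCCCC3)[nH]c2-c2ccccc2)cc1`, differs from compound 3 by cyclohexyl in place of 5-oxopyrrolidin-2-yl on a saturated chain carbon bound to a sulfur. Among the compounds with values here, no measured step exchanges a ring with a hetero atom for a ring of carbon only, so the expectation rests on the modest size of a 2.1-fold higher number from compound 1 to compound 3 (0.33 log units; beyond the scatter) alone: a change of at most modest size is expected, with the direction open. Compound 4 is therefore expected to give 250 nM, spanning 80 nM to 800 nM, an expected step of a 1.4-fold lower number from compound 3 to compound 4 (0.16 log units; within the scatter).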

Compound 4, half-maximal inhibitory concentration: 100 nM
Compound 4: the middle estimate sits 2.5-fold (0.40 log units) above what was measured, and the stated range covers the measured number.
By their numbers in this assay, from the lowest: compounds 4, 1, 2 and 3 (each within the scatter of the next, the first and the last beyond it).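

In this assay the step of a 3.6-fold lower number from compound 3 to compound 4 (0.56 log units; beyond the scatter) shows that this place, on a saturated chain carbon bound to a sulfur, tolerates a ring of carbon only, with no hydrogen-bond donor or acceptor. The step of a 1.7-fold lower number from compound 1 to compound 4 (0.23 log units; within the scatter) lies within the scatter, so cyclohexyl and the oxygen-bearing ring of compound 1 cannot be told apart here.

The compounds shown leave open how phenyl, a longer chain such as hexyl, or a cyclohexyl ring carrying an amine or a carboxylic acid would compare at this place. Nothing measured here accounts for these steps.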